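Fluorine added to a benzoxaborole core already at the solubility ceiling

The compounds below may be only part of what the source reports. "The series", "measured", "known", "first", "only" and "open" are said of these compounds alone.

Measured so far:
- compound 1, `O=C(Nc1cccn(Cc2ccccc2)c1=O)c1ccc2c(c1)B(O)OC2`: 3 ug/mL
- compound 2, `O=C(Nc1cccn(Cc2ccccc2)c1=O)c1cc(F)c2c(c1)B(O)OC2`: 8 ug/mL
- compound 3, `OB1OCc2ccc(Oc3nnn[nH]3)cc21`: > 1000 ug/mL

All three compounds were tested in an ADME assay for solubility, in simulated intestinal fluid; on this read-out lower numbers stand for lower solubility and higher numbers for higher solubility. Compound 1 and compound 2 share a core and differ only in one place: fluoro in place of hydrogen on an aromatic carbon. That change gave a 2.7-fold higher number from compound 1 to compound 2 (0.43 log units; beyond the scatter). For compound 3 the result is not a number but a limit of the assay, reported as > 1000 ug/mL. How the core of compound 3 differs from the core of compound 1 is not broken down here.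

Compound 4, `OB1OCc2ccc(Oc3nnn[nH]3)c(F)c21`, has not yet been measured. It differs from compound 3 in one place: fluoro in place of hydrogen on an aromatic carbon. Among the compounds with values here, this is the same kind of change as the one from compound 1 to compound 2, but its surroundings are not identical: in compound 2 the fluoro sits meta to a large group, whereas in compound 4 it sits ortho to a group of 6 heavy atoms.

In this assay the estimated step is a number no higher from compound 3 to compound 4 (the limit leaves the size open), set beside the earlier measured step. The expectation rests on two things: compound 3 already sits at the limit (the limit of > 1000 ug/mL in this assay, at which 1 of the 3 values shown sits), so any gain cannot be seen, and the earlier step on the other core was only modest. Compound 4 is therefore expected to come out at about 1000 ug/mL, most likely again as a limit rather than a number.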

Compound 4, solubility: > 1000 ug/mL
Compound 4: only a limit was reported (the forecaster's own chance of this, stated with the estimate: 80%); the middle value sits exactly at the limit.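

In this assay, compound 4 gives > 1000 ug/mL, which is a limit of the assay and not a number. Compound 3 also carries a limit, so no step between compound 3 and compound 4 can be read: the limit of > 1000 ug/mL in this assay, at which 2 of the 4 values shown sit.

On these data alone, whether fluoro in place of hydrogen moves the read-out of this assay at all on the core of compound 3, and by how much, stays open.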